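This account rests on a few compounds, and the source may have more. Where it says the series, first, only, none or still open, it means among the compounds named here.

Compound 1 `COc1cc(/C=C/C(=O)c2cccc(-n3cc(-c4ccccc4)[nH]c3=O)c2)ccc1O` was tested in a functional assay on SK-MEL-5 cells (Homo sapiens) for inhibition (on this read-out higher numbers stand for weaker inhibition of growth and lower numbers for stronger inhibition of growth), where compound 1 gives 1590 nM. Compound 2 `O=C(/C=C/c1cccc(O)c1)c1cccc(-n2cc(-c3ccccc3)[nH]c2=O)c1` differs from it only in the aryl group on the chain, and in this assay compound 2 gives 3180 nM; the step of a 2.0-fold higher number from compound 1 to compound 2 (0.30 log units; within the scatter) is within the scatter, so the two numbers cannot be told apart. Compound 3 `COc1ccc(-c2cn(-c3cccc(C(=O)/C=C/c4ccc(O)c(OC)c4)c3)c(=O)[nH]2)cc1` is not yet measured. Relative to compound 1 it carries methoxy in place of hydrogen on an aromatic carbon. Within the data shown here, no measured step touches the phenyl group on the shared core: the single measured step changes the aryl group on the chain, and it stays within the scatter. With nothing to argue for a shift, the expected step of a 1.0-fold higher number from compound 1 to compound 3 (0.00 log units; within the scatter) is none beyond the scatter. Compound 3 is therefore estimated at 1600 nM in this assay, with a range from 600 nM to 4500 nM.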

Compound 3, concentration for 50% growth inhibition: 2630 nM
Estimate against measurement, compound 3: 1.6-fold (0.22 log units) below; the range from low to high includes it.
By their numbers in this assay, from the lowest: compounds 1, 3 and 2 (each within the scatter of the next).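

Among these compounds, this is the first measured change to the phenyl group on the shared core; the earlier step touched only the aryl group on the chain. In this assay, going from phenyl to 4-methoxyphenyl gives a 1.7-fold higher number from compound 1 to compound 3 (0.22 log units; within the scatter), so the two numbers cannot be told apart, and adding a methoxy at this aromatic carbon, para to a large group, produces no shift that this read-out can resolve. No measurement at hand offers an explanation for this result.

The compounds shown leave open whether a different group on the same carbon, such as an amine or a carboxylic acid, would move the number beyond the scatter. They also leave open whether the methoxy would behave the same way alongside the 3-hydroxyphenyl group on the chain of compound 2.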